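Methylsulfanyl for bromo on the benzylidene aryl

The source may hold more compounds than are shown below. What is called first, only, known or untested is meant among the compounds shown, and "the series" means these compounds.

Among the compounds with values here, compound 1, `O=C(O)c1ccc(C(=O)/C(=C\c2ccc(Br)cc2)SCc2ccc(Br)cc2)cc1`, is the only member of this small set with a numerical result: in a functional assay on DU-145 cells (Homo sapiens) for inhibition, read by trypan blue exclusion, with a stated time of 96 h (a higher number here means a weaker inhibitor of growth, a lower number a stronger inhibitor of growth), compound 1 gives 1000 nM. Compound 2, `Cc1ccc(S/C(=C/c2cnc3ccccc3c2)C(=O)c2ccc(Cl)cc2)cc1`, stands apart. In this assay compound 2 gives > 100000 nM, which is a limit of the assay rather than a number. That result is the limit of > 100000 nM in this assay, at which 1 of the 2 values shown sits. Within the data shown here, no pair of measured compounds differs in a single place, so no measured step can be drawn between them. Compound 3, `CSc1ccc(/C=C(/SCc2ccc(Br)cc2)C(=O)c2ccc(C(=O)O)cc2)cc1`, is the compound still to be tested; it differs from compound 1 by methylsulfanyl in place of bromo on an aromatic carbon. One group leaves and another enters at that carbon, and the step of a 1.5-fold higher number from compound 1 to compound 3 (0.18 log units; within the scatter) is expected to be small, with no direction that would stand out beyond the usual scatter. Compound 3 is therefore estimated to give about 1500 nM in this assay, within a range from 300 nM to 8000 nM.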

Compound 3, concentration for 50% growth inhibition: 10000 nM
Compound 3: middle estimate off by 6.7-fold (0.82 log units), on the low side; the measured number lies above the stated range.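

In this assay, the aromatic carbon that carries bromo in compound 1 proves sensitive to this exchange: methylsulfanyl in place of bromo gives a 10-fold higher number from compound 1 to compound 3 (1.00 log units; beyond the scatter). The higher number means that compound 3 is the weaker inhibitor of growth, so these two groups cannot be treated as interchangeable at this carbon on the core of compound 1. The data shown offer no measurement that accounts for this step.

Within the data shown here, the single pair leaves open whether the sulfur or the added methyl carbon of methylsulfanyl matters more, a question that methoxy or methyl at the same carbon could help to separate. It also leaves open whether chloro or an amine there would stay close to compound 1, and whether the same exchange would have a similar effect on another core.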